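Adding an Acetoxy Group to Compound 1

This account rests on a few compounds, and the source may have more. Where it says the series, first, only, none or still open, it means among the compounds named here.

Of the compounds shown here, two that share one core have been tested in an ADME assay on Raji cells (Homo sapiens) for cytotoxicity, read by CellTiter-Glo, with a stated time of 72 h; on this read-out higher numbers stand for an effect only at larger amounts of compound and lower numbers for an effect already at smaller amounts. Compound 1 `CC1=C2CC(C)(C)/C=C/C/C(C)=C\C3=C[C@H](C)C[C@]3(O2)C1=O` gives 26000 nM, the highest of the two numbers. Compound 2 `CC1=C2CC(C)(C)/C=C/C(=O)/C(C)=C\C3=C[C@H](C)C[C@]3(O2)[C@@]1(O)C#N` gives 21200 nM, and the gap between these two values lies within the scatter, so neither can be called more or less toxic to the cells than the other. Compound 3 `CC(=O)O[C@H]1/C=C/C(C)(C)CC2=C(C)C(=O)[C@]3(C[C@@H](C)C=C3/C=C\1C)O2` has not yet been measured. It differs from compound 1 by acetoxy in place of hydrogen on a saturated ring carbon. Going by the values given here, no measured pair shows what such a change does, so no guidance exists beyond the two values above. The expected step in this assay is a 1.2-fold lower number from compound 1 to compound 3 (0.07 log units; within the scatter), which would keep compound 3 within the scatter of compound 1. Compound 3 is therefore estimated to give about 22000 nM, with a likely range from 8000 nM to 60000 nM.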

Compound 3, half-maximal effective concentration: 26000 nM
Beside the measured number, compound 3's estimate is 1.2-fold (0.07 log units) below it; low and high end bracket the measured number.
By their numbers in this assay, from the lowest: compounds 2, 1 and 3 (each within the scatter of the next).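

Putting acetoxy in place of hydrogen on a saturated ring carbon gives no change at the digits printed from compound 1 to compound 3 (within the scatter) in this assay. Going by these compounds alone, this is the first measured pair here that differs in only one place, and it shows that this ring carbon of the shared core can carry acetoxy with no change in the number that can be told from scatter. No measurement shown here offers an explanation for this result.

As far as these compounds go, whether the same ring carbon would give a similar number with an amine, a carboxylic acid or a longer chain in place of hydrogen remains open. From the compounds shown here alone, it is also open whether acetoxy on a different ring carbon of the shared core would leave the number equally unchanged.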